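A few compounds are considered here, and "the series" means these few. Any claim that something is new, unique, unknown or untested is made for them only; others in the source may bear on it.

In a functional assay on HCT-116 cells (Homo sapiens) for antiproliferative activity, read by MTT assay, with a stated time of 72 h; on this read-out lower numbers stand for stronger inhibition and higher numbers for weaker inhibition:
- compound 1 `NC1=NC2(CCOCC2)N(OCCCOc2ccc(F)cc2)C(N)=N1`: 3280 nM
- compound 2 `NC1=NC2(CCOCC2)N(OCCCOc2ccc(Cl)cc2Cl)C(N)=N1`: 880 nM

Compound 2, at 880 nM, has the lower of these two numbers and so shows the stronger inhibition. Compound 3 `NC1=NC2(CCOCC2)N(OCCCOc2cc(Cl)c(Cl)cc2Cl)C(N)=N1` differs from it by one change: chloro in place of hydrogen on an aromatic carbon, (chloro in place of hydrogen on an aromatic carbon). For the measured compounds named here, only one measured step bears on this, a 3.7-fold lower number from compound 1 to compound 2 (0.57 log units; beyond the scatter), a modest change that turned the 4-fluorophenyl group into 2,4-dichlorophenyl. A single step is thin support, so a smaller change in the same direction in this assay is expected: the estimated step is a 2.2-fold lower number from compound 2 to compound 3 (0.34 log units; beyond the scatter). For compound 3 the estimated value is 400 nM, with an expected range of 150 nM to 1100 nM.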

Compound 3, half-maximal inhibitory concentration: 2750 nM
For compound 3 the middle estimate is 6.9-fold (0.84 log units) below the measured one, and the stated range ends below it.
By their numbers in this assay, from the lowest: compound 2; then compounds 3 and 1 (each within the scatter of the next).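

In this assay, one more chloro on the 2,4-dichlorophenyl group does not extend the earlier gain: placing it ortho to a chloro group and para to a chloro group gives a 3.1-fold higher number from compound 2 to compound 3 (0.49 log units; beyond the scatter). Adding chlorine to this ring therefore does not simply lower the number, and the 2,4,5-trichlorophenyl group stands level with 4-fluorophenyl, at a 1.2-fold lower number from compound 1 to compound 3 (0.08 log units; within the scatter). Nothing available explains this reversal.

On these data alone, whether a methoxy group at this same position would also raise the number remains open. So does whether a longer chain to the ring would change the picture.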